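Swapping the Substituent on the Benzylidene Ring

A few compounds are considered here, and "the series" means these few. Any claim that something is new, unique, unknown or untested is made for them only; others in the source may bear on it.

The compounds share one core, seen in compound 1 `O=C1/C(=C\c2ccc(F)cc2)c2ccccc2N1c1c(Cl)cccc1Cl`, and differ only in the aromatic ring hanging from the double-bonded chain carbon. In a functional assay on HuTu80 cells (Homo sapiens) for cytotoxicity, read by MTT assay, with a stated time of 72 h (a lower number here means that less compound is needed, a higher number that more compound is needed for the effect), compound 1 gives 8 ug/mL. Compound 2 `O=C1/C(=C\c2cccc(Oc3ccccc3)c2)c2ccccc2N1c1c(Cl)cccc1Cl` carries a phenoxy group on that ring and in this assay gives 10 ug/mL. Compound 3 `COc1ccc(/C=C2\C(=O)N(c3c(Cl)cccc3Cl)c3ccccc32)cc1` carries a methoxy group there. For compound 3 this assay reports only a limit, > 100 ug/mL, which is the limit of > 100 ug/mL in this assay, at which 1 of the 3 values shown sits. The step from fluoro to methoxy, an at least 12-fold higher number from compound 1 to compound 3 (1.09 log units; beyond the scatter), was the largest movement among the measured compounds.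

Compound 4 `O=C1/C(=C\c2cccc(Br)c2)c2ccccc2N1c1c(Cl)cccc1Cl` is the next step from compound 3: 3-bromophenyl in place of 4-methoxyphenyl on a double-bonded chain carbon bound to a double-bonded ring carbon. This undoes the methoxy that made compound 3 so weak and returns to a halogen, as in compound 1. Because an at least 12-fold higher number from compound 1 to compound 3 (1.09 log units; beyond the scatter) went so strongly toward a higher number when methoxy came in, the reverse move is expected to bring the number back down, toward the level of compound 1 and compound 2. For compound 4 the expected change is an at least 8.3-fold lower number from compound 3 to compound 4 (0.92 log units; beyond the scatter), and its value in this assay is estimated at 12 ug/mL, within a range from 5 ug/mL to 40 ug/mL.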

Compound 4, concentration for half-maximal effect: 7 ug/mL
The estimate for compound 4 lay 1.7-fold (0.23 log units) above the measured number; low and high end bracket the measured number.
By their numbers in this assay, from the lowest: compounds 4, 1 and 2 (each within the scatter of the next). At a limit, above all of these: compound 3.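

In this assay, the change from 4-methoxyphenyl to 3-bromophenyl on the double-bonded chain carbon gives an at least 14-fold lower number from compound 3 to compound 4 (1.15 log units; beyond the scatter) and shows that the weak result of compound 3 does not carry over to this bromine-bearing ring. The comparisons with the other two rings are a 1.1-fold lower number from compound 1 to compound 4 (0.06 log units; within the scatter) and a 1.4-fold lower number from compound 2 to compound 4 (0.15 log units; within the scatter) and place compounds 1, 2 and 4 together, with compound 3 the only one of the four apart from them. The size of the step from the methoxy compound rests on a limit and not on a number: the limit of > 100 ug/mL in this assay, at which 1 of the 4 values shown sits.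

This swap changes both the group and where it sits on the ring, so the compounds shown cannot separate those two changes. From the compounds shown here alone, whether an amine or a carboxylic acid on this ring would behave like the halogens or like methoxy also stays open.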